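Swapping the aryl group: compound 3 in this assay

A few compounds are considered here, and "the series" means these few. Any claim that something is new, unique, unknown or untested is made for them only; others in the source may bear on it.

Compound 2 `CCC1=C(O)c2c(oc(-c3ccc(C)c(F)c3)cc2=O)C(CC)(CC)C1=O` gives 2.95 uM in a functional assay on KBVIN cells (Homo sapiens) for antiproliferative activity, read by sulforhodamine B assay, with a stated time of 3 days (a higher number here means that more compound is needed for the effect, a lower number that less compound is needed), and compound 1 `CCC1=C(O)c2c(oc(-c3ccccc3OC)cc2=O)C(CC)(CC)C1=O` gives 3.26 uM; the two stand within the scatter of each other, as the step of a 1.1-fold lower number from compound 1 to compound 2 (0.04 log units; within the scatter) shows. Compound 3 `CCC1=C(O)c2c(oc(-c3cc(C)cc(C)c3)cc2=O)C(CC)(CC)C1=O` differs from compound 2 by 3,5-dimethylphenyl in place of 3-fluoro-4-methylphenyl on an aromatic carbon. Going by the values given here, the only step known, the change of the aryl group from compound 1 to compound 2, stayed within the scatter, so for compound 3 a step of about a 1.0-fold higher number from compound 2 to compound 3 (0.01 log units; within the scatter) is expected, with no change beyond the scatter. Compound 3 is therefore estimated at 3 uM, between 1.5 uM and 6 uM.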

Compound 3, concentration for half-maximal effect: 0.45 uM
Compound 3: middle estimate off by 6.7-fold (0.82 log units), on the high side; measured number outside the range, below it.
By their numbers in this assay, from the lowest: compound 3; then compounds 2 and 1 (each within the scatter of the next).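

In this assay the aryl group next to the ring oxygen turned out to matter: 3,5-dimethylphenyl in place of 3-fluoro-4-methylphenyl gave a 6.6-fold lower number from compound 2 to compound 3 (0.82 log units; beyond the scatter) and in place of 2-methoxyphenyl gave a 7.2-fold lower number from compound 1 to compound 3 (0.86 log units; beyond the scatter) while the earlier aryl swap had stayed within the scatter. This position can therefore move the number beyond the scatter, although both steps are modest. Nothing available explains the drop. The compounds shown leave open whether the pair of methyl groups is what counts, and how an aryl group carrying an amine or a longer alkyl chain would stand.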